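This account rests on a few compounds, and the source may have more. Where it says the series, first, only, none or still open, it means among the compounds named here.

Measured compounds:
- compound 1 `N#CC1=C(N)Oc2c(c3nc4ccccc4nc3c3ccccc23)C12C(=O)N(Cc1cnnn1-c1cccc(Br)c1)c1ccccc12`: > 50000 nM
- compound 2 `N#CC1=C(N)Oc2c(N)cc3nc4ccccc4nc3c2C12C(=O)N(Cc1cnnn1-c1ccccc1Br)c1ccccc12`: 12400 nM

Of the compounds shown here, two have been tested in a functional assay on HCT-116 cells (Homo sapiens) for antiproliferative activity, read by MTT assay, with a stated time of 48 h; on this read-out higher numbers stand for weaker inhibition and lower numbers for stronger inhibition. For compound 1 the result is a limit rather than a number: in this assay compound 1 gives > 50000 nM, which is the limit of > 50000 nM in this assay, at which 1 of the 2 values shown sits. Among the compounds with values here, compound 2 is the only one with a true number, giving 12400 nM in this assay, so it stands as the sole reference point. Compound 3 `CCOc1ccc(-n2nncc2CN2C(=O)C3(C(C#N)=C(N)Oc4c(N)cc5nc6ccccc6nc5c43)c3ccccc32)cc1` has not yet been measured. It differs from compound 2 in one place: 4-ethoxyphenyl in place of 2-bromophenyl on an aromatic nitrogen. Within the data shown here, no pair of measured compounds shares this change, so there is no measured step to lean on. The expectation is that the step of a 1.2-fold higher number from compound 2 to compound 3 (0.08 log units; within the scatter) stays within the usual scatter, with no clear direction. Compound 3 is therefore expected to give about 15000 nM, between 5000 nM and 50000 nM.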

Compound 3, half-maximal inhibitory concentration: > 50000 nM
Compound 3 ended at the assay's limit (the forecaster's own chance of this, stated with the estimate: 25%); middle value at least 3.3-fold (0.52 log units) from the limit.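

Within the data shown here, this is the first measured step at this position. In this assay, putting 4-ethoxyphenyl in place of 2-bromophenyl on the aromatic nitrogen gives an at least 4.0-fold higher number from compound 2 to compound 3 (0.60 log units; beyond the scatter), so the group at this position can weaken inhibition even with the rest of the molecule unchanged. Compound 3 gives a limit rather than a true number, so the step has only a minimum size and its full size stays unknown, and the result joins another at the same limit: the limit of > 50000 nM in this assay, at which 2 of the 3 values shown sit.

The change alters both the substituent, bromine against ethoxy, and its location on the phenyl ring, and the compounds shown cannot tell these two effects apart. A plain phenyl, 4-bromophenyl or 2-ethoxyphenyl group on this nitrogen would help to separate them.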